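Aryl urea series: chloro for methoxy at compound 3

The source may hold more compounds than are shown below. What is called first, only, known or untested is meant among the compounds shown, and "the series" means these compounds.

Three compounds of the series have numbers in an assay on isolated protein (Homo sapiens) for inhibition of HEXA/HEXB (Bos taurus), using a Dixon plot; a lower number here means a stronger inhibitor, a higher number a weaker inhibitor. Compound 1 `CC(=O)N[C@H]1/C(=N/NC(=S)Nc2ccccc2)O[C@H](CO)[C@@H](O)[C@@H]1O` gives 30000 nM. Compound 2 `CC(=O)N[C@H]1/C(=N/NC(=O)Nc2ccc3ccccc3c2)O[C@H](CO)[C@@H](O)[C@@H]1O` gives 47 nM. Compound 3 `COc1ccc(NC(=O)N/N=C2\O[C@H](CO)[C@@H](O)[C@H](O)[C@H]2NC(C)=O)cc1` gives 413 nM, the second highest of the three numbers; against compound 2 it stands higher by a margin beyond the scatter, and against compound 1 it stands lower, again beyond the scatter. Among the measured compounds shown here, no two of the measured compounds differ in only one place, so no single step between measured compounds can be read off, and the spread from compound 1 through compound 3 to compound 2 shows only that changes at the aryl end of the shared core move the number across a wide span.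

Compound 4 `CC(=O)N[C@H]1/C(=N/NC(=O)Nc2ccc(Cl)cc2)O[C@H](CO)[C@@H](O)[C@@H]1O` is not yet measured. It differs from compound 3 in one place: chloro in place of methoxy on an aromatic carbon. For the measured compounds named here, nothing among the measured compounds shows what this exchange does in this assay. The expectation is for a small step, with a lower number somewhat more likely than a higher one, but not clearly beyond the scatter. Compound 4 is therefore estimated at 250 nM, with a range from 80 nM to 900 nM. The implied step a 1.7-fold lower number from compound 3 to compound 4 (0.22 log units; within the scatter) is expected to stay close to the scatter.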

Compound 4, inhibition constant: 170 nM
For compound 4 the middle estimate is 1.5-fold (0.17 log units) above the measured one, and the stated range covers the measured number.
By their numbers in this assay, from the lowest: compound 2; then compound 4; then compound 3; then compound 1.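

In this assay, among the compounds shown here, chloro in place of methoxy on an aromatic carbon para to a large group gives a 2.4-fold lower number from compound 3 to compound 4 (0.39 log units; beyond the scatter), and this is the only step so far that isolates a single place. The position is therefore not indifferent to the group it carries, even in an exchange this small, although the size of the step is only modest. Moving from methoxy, with its hydrogen-bond acceptor, to chloro, which has none, costs nothing in this assay, while nothing at hand accounts for the lower number.

For the compounds shown here, with only two groups compared at this position, it remains open whether the lower number is particular to chloro or would also appear with an amine, a carboxylic acid, a methyl group or a longer chain. Going by these compounds alone, it is also open whether the same exchange would give a step of similar size on an aryl group such as the one in compound 2, or with the thiocarbonyl of compound 1 in place of the carbonyl.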